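Swapping Chlorophenyl for Methoxyphenyl on the Ether Chain

This account rests on a few compounds, and the source may have more. Where it says the series, first, only, none or still open, it means among the compounds named here.

Compound 1 `NC1=NC2(CCSCC2)N(OCCCOc2cccc(Cl)c2)C(N)=N1` gives 88.3% in an assay on isolated protein for inhibition of Dihydrofolate reductase (Homo sapiens), read by spectrophotometry, using NADPH, with stated times of 5 s and 6 min, tested at 5 uM (on this read-out higher numbers stand for a stronger effect at the one concentration tested and lower numbers for a weaker effect), the only plain number shown among the two measured compounds. Compound 2 `NC1=NC2(CCOCC2)N(OCCCOc2ccc(Cl)c(Cl)c2)C(N)=N1` gives > 90% in this assay, which is a limit of the assay rather than a number (the limit of > 90% in this assay, at which 1 of the 2 values shown sits). Compound 3 `COc1ccc(OCCCON2C(N)=NC(N)=NC23CCSCC3)cc1` differs from compound 1 by 4-methoxyphenyl in place of 3-chlorophenyl on an oxygen on a saturated carbon. For the measured compounds named here, no measured step of this kind exists here, so the size of the change in this assay is uncertain; the most likely outcome is a small decrease or none beyond the scatter. Compound 3 is therefore expected to give 80% (between 60% and 92%). The expected step of a number 8.3 percentage points lower from compound 1 to compound 3 (within the scatter) is accordingly modest.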

Compound 3, a percentage reported as inhibition, at one concentration (the size of the read-out at that concentration, not a potency): 81.3%
Compound 3: the middle estimate sits 1.3 percentage points below what was measured, within the range that was stated.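

The step is a number 7 percentage points lower from compound 1 to compound 3 (within the scatter), so in this assay 4-methoxyphenyl in place of 3-chlorophenyl does not separate the two compounds. For this one pair, the place on an oxygen on a saturated carbon accepts a different aryl group without a change beyond the scatter. Nothing given here bears on the cause of this step.

A reading at one concentration is not a potency, and this swap alters both the substituent and its ring position, so neither can be judged alone. Going by these compounds, whether an amine or a carboxylic acid on the phenyl ring, or a longer ether chain, would keep this level of inhibition remains open.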